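The source may report more compounds than this note shows. Statements on the series, on what has been measured and on what is new or still open speak of the compounds shown alone.

The set brings together three measured compounds and one still to be measured, all read in a functional assay on A549 cells (Homo sapiens) for cytotoxicity, read by sulforhodamine B assay, with a stated time of 72 h; a lower number here means a stronger inhibitor, a higher number a weaker inhibitor. Compound 1 `O=c1c(CNc2ccc(S(=O)(=O)Nc3nccs3)cc2)coc2ccccc12` gives 25600 nM. Compound 2 `Cc1cc(NS(=O)(=O)c2ccc(NC3=NC(=O)/C(=C\c4coc5ccccc5c4=O)S3)cc2)no1` returns only a limit of the assay, > 100000 nM. Compound 3 `Cc1cc(NS(=O)(=O)c2ccc(N3C(=O)/C(=C/c4coc5ccccc5c4=O)N=C3c3ccc(Cl)cc3)cc2)no1` likewise returns a limit, > 100000 nM. On the numbers shown, compound 2 therefore stands at the weak end, at the limit of > 100000 nM in this assay, at which 2 of the 3 values shown sit, and only compound 1 carries a real value. Compound 4 `O=C1N=C(Nc2ccc(S(=O)(=O)Nc3nccs3)cc2)S/C1=C/c1coc2ccccc2c1=O` is the compound awaiting measurement. It differs from compound 2 in one place: 1,3-thiazol-2-yl in place of 5-methyl-1,2-oxazol-3-yl on a sulfonamide nitrogen. For the measured compounds named here, no measured pair isolates this exchange, so the size of the step has to be judged without a direct precedent. The 1,3-thiazol-2-yl sulfonamide also appears in compound 1, on a different core, with 25600 nM, but compound 1 shares little else with compound 2. The step from compound 2 to compound 4 in this assay is expected to be a number no higher from compound 2 to compound 4 (the limit leaves the size open), most likely nothing beyond the scatter. Compound 4 is accordingly estimated at 100000 nM, within 30000 nM to 300000 nM, with a real chance that only a limit is reported again.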

Compound 4, half-maximal inhibitory concentration: > 100000 nM
Compound 4 was reported as a limit (the forecaster's own chance of this, stated with the estimate: 65%); the middle value sits exactly at the limit.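

For the compounds shown here, compound 2 and compound 4 are both reported only as limits in this assay, so no step between them can be read. The compounds shown leave open whether 1,3-thiazol-2-yl in place of 5-methyl-1,2-oxazol-3-yl on a sulfonamide nitrogen changes the reading at all.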